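This account rests on a few compounds, and the source may have more. Where it says the series, first, only, none or still open, it means among the compounds named here.

Within the data shown here, compound 1, with structure `O=C(Nc1cccc(-c2oc3cc(-c4ccc(F)cc4)ccc3c(=O)c2O)c1)c1ccccc1F`, is the lower of the two numbers so far recorded. In a functional assay on A549 cells (Homo sapiens) for antiproliferative activity, read by CCK-8 assay, with a stated time of 72 h (on this read-out lower numbers stand for stronger inhibition and higher numbers for weaker inhibition), compound 1 gives 4410 nM, while compound 2, with structure `O=C(Nc1cccc(-c2oc3cc(-c4ccc(F)cc4)ccc3c(=O)c2O)c1)c1cccc(F)c1`, gives 15400 nM. Among the measured compounds shown here, the one comparison on hand, a 3.5-fold higher number from compound 1 to compound 2 (0.54 log units; beyond the scatter), moves the number in the weaker direction when the group on the carbonyl carbon is exchanged. Compound 3, with structure `O=C(Nc1cccc(-c2oc3cc(-c4ccc(F)cc4)ccc3c(=O)c2O)c1)c1ccc(-c2ccccc2)cc1`, differs from compound 1 at the same carbonyl carbon: 4-phenylphenyl in place of 2-fluorophenyl on a carbonyl carbon. That comparison bears on the present case only loosely, since the new group is larger and lacks the fluorine. Because the exchange from compound 1 to compound 2 gave a 3.5-fold higher number from compound 1 to compound 2 (0.54 log units; beyond the scatter), a shift toward a higher number is expected here as well, likely of a similar or somewhat larger size, a 2.5-fold higher number from compound 1 to compound 3 (0.40 log units; beyond the scatter). For compound 3 the expected value in this assay is therefore 11000 nM, with a range from 3000 nM to 40000 nM.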

Compound 3, half-maximal inhibitory concentration: > 100000 nM
Compound 3 gave a limit, no number; the forecaster's own chance of this, stated with the estimate: 10%; at least 9.0-fold (0.95 log units) between middle value and limit.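

In this assay compound 3 gives only a limit and not a number, > 100000 nM: the limit of > 100000 nM in this assay, at which 1 of the 3 values shown sits. Placing 4-phenylphenyl on the carbonyl carbon gives an at least 22-fold higher number from compound 1 to compound 3 (1.35 log units; beyond the scatter), and an at least 6.4-fold higher number from compound 2 to compound 3 (0.81 log units; beyond the scatter). The earlier pair showed only a shift between 2-fluorophenyl and 3-fluorophenyl, whereas this change shows that the group on this carbonyl carbon can carry the read-out as far as the limit of the assay.

The compounds shown do not separate the entry of the second aromatic ring from the loss of the fluorine, as the two happen together in this change. On these data alone, how a plain phenyl, a 4-fluorophenyl or a small methyl group on the same carbonyl carbon would compare in this assay remains open.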